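The compounds below may be only part of what the source reports. "The series", "measured", "known", "first", "only" and "open" are said of these compounds alone.

In an assay on HEK-293T cells for antagonist activity at vitamin D3 receptor (Homo sapiens), read by a luciferase reporter, with a stated time of 24 h (a higher number here means a weaker inhibitor, a lower number a stronger inhibitor), the measured compounds are:

Compound 1 `CCC(CC)n1c(-c2ccc(OCc3c(-c4c(Cl)cccc4Cl)noc3C(C)C)cc2F)nc2ccc(C(=O)O)cc21`: in this assay compound 1 reaches only the limit > 10000 nM.
Compound 2 `CC(C)c1onc(-c2c(Cl)cccc2Cl)c1COc1ccc(-c2nc3ccc(C(=O)O)cc3n2Cc2ccc(F)cc2)cc1`: compound 2 gives 1140 nM.
Compound 3 `CC(C)c1onc(-c2c(Cl)cccc2Cl)c1COc1ccc(-c2nc3ccc(C(=O)O)cc3n2CC2CCCCC2)c(F)c1`: compound 3 gives 840 nM.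

The value of compound 1 is a limit of this assay and not a number (the limit of > 10000 nM in this assay, at which 1 of the 3 values shown sits). Compound 2 and compound 3 give numbers that lie within the usual scatter of one another, so neither can be set above the other. Compound 4 `CCCn1c(-c2ccc(OCc3c(-c4c(Cl)cccc4Cl)noc3C(C)C)cc2)nc2ccc(C(=O)O)cc21` is not yet measured; it differs from compound 2 in one place, (ethyl in place of 4-fluorophenyl on a saturated chain carbon bound to an aromatic nitrogen), so that the 4-fluorobenzyl of compound 2 becomes a propyl. Going by the values given here, the only measured step that bears on this position, an at least 11-fold lower number from compound 1 to compound 3 (1.07 log units; beyond the scatter), shows that replacing a short branched alkyl with a cyclohexylmethyl gives a large drop in the number; compound 4 goes the other way, from an aromatic ring to a short chain. Compound 4 is therefore expected to show a markedly higher number than compound 2, a 5.3-fold higher number from compound 2 to compound 4 (0.72 log units; beyond the scatter), possibly reaching the limit. The estimate for compound 4 is 6000 nM, in a range from 2000 nM to 20000 nM.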

Compound 4, half-maximal inhibitory concentration: 1400 nM
Compound 4: middle estimate off by 4.3-fold (0.63 log units), on the high side, outside the stated range (below it).
By their numbers in this assay, from the lowest: compounds 3, 2 and 4 (each within the scatter of the next). At a limit, above all of these: compound 1.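

In this assay the change from 4-fluorobenzyl to propyl gives a 1.2-fold higher number from compound 2 to compound 4 (0.09 log units; within the scatter) and so leaves the two numbers indistinguishable. The earlier compounds shown here showed only that this place could matter; here, the 4-fluorophenyl, with its aromatic ring and 7 heavy atoms, gives way to an ethyl of 2 heavy atoms with no measurable change, so compound 2 does not depend on that ring to hold its number in this assay. Nothing measured here explains why this large change in the group leaves the number unmoved.

The compounds shown leave open how far this tolerance extends, for instance to a longer chain such as hexyl or to a propyl ending in an amine or a carboxylic acid. They also leave open how an unsubstituted benzyl would compare with the 4-fluorobenzyl of compound 2.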